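The compounds below may be only part of what the source reports. "The series", "measured", "known", "first", "only" and "open" are said of these compounds alone.

Of the compounds shown here, two have been tested in a functional assay on the whole organism (strain albino) for inhibition, with Rattus norvegicus as the target, read by paw edema, with a stated time of 4 h, at a dose of 0.28 mmol/kg by the oral route; a higher number here means more inhibition at the dose given (going by the name of the read-out), a lower number less inhibition. Compound 1 `C=CCn1c(SCC(=O)c2ccccc2)nnc1-c1ccc(OC)c(OC)c1` gives 72% there. Compound 2 `CCn1c(SC/C(=N/O)c2ccccc2)nnc1-c1ccc(OC)c(OC)c1` gives 82% and thus holds the highest of the two numbers, but the gap to compound 1 lies within the scatter, so the two are not separable on the numbers shown. The two structures differ in more than one place, so no single step can be read off between them.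

Compound 3 `CCn1c(SCC(=O)c2ccccc2)nnc1-c1ccc(OC)c(OC)c1` has not yet been measured. It differs from compound 2 in one place: a group of 8 heavy atoms (7 carbon, 1 oxygen; one six-membered aromatic ring of carbon only) in place of a group of 9 heavy atoms (7 carbon, 1 nitrogen, 1 oxygen; one six-membered aromatic ring of carbon only), on a saturated chain carbon bound to a sulfur. In compound 1 the same benzoyl group is already present with a different substituent on the core, and compound 1 gives 72%. On this basis the step of a number 8 percentage points lower from compound 2 to compound 3 (within the scatter) is expected to be small and within the scatter. For compound 3 an inhibition of about 74% is estimated, with a range from 60% to 86%.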

Compound 3, a percentage reported as inhibition, in the whole organism at one dose (the size of the read-out at that dose, not a potency): 73%
Beside the measured number, compound 3's estimate is 1 percentage points above it; low and high end bracket the measured number.
By their numbers in this assay, from the lowest: compounds 1, 3 and 2 (each within the scatter of the next).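

Exchanging the group of 9 heavy atoms, with its 1 hydrogen-bond donor, for benzoyl on a saturated chain carbon bound to a sulfur gives a number 9 percentage points lower from compound 2 to compound 3 (within the scatter) in this assay and so does not resolve an effect of this change. Methyl in place of vinyl on a saturated chain carbon bound to an aromatic nitrogen gives a number 1 percentage points higher from compound 1 to compound 3 (within the scatter) and is likewise not resolved at this single dose. Nothing measured here bears on why either step is of this size.

From the compounds shown here alone, it remains open whether a carboxylic acid or an amine in place of benzoyl on a saturated chain carbon bound to a sulfur would give a step beyond the scatter. The same question stands for a longer chain in place of methyl on a saturated chain carbon bound to an aromatic nitrogen.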